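The source may hold more compounds than are shown below. What is called first, only, known or untested is meant among the compounds shown, and "the series" means these compounds.

Measured so far:
compound 1 `C#CCNC1CCc2c(SCCc3ccc(C)cc3)cccc21` — 4520 nM
compound 2 `C#CCNC1CCc2c(SCc3ccc(Cl)cc3Cl)cccc21` — 22300 nM

In an ADME assay on isolated protein for inhibition of Amine oxidase [flavin-containing] B (Homo sapiens) (a lower number here means a stronger inhibitor, a higher number a weaker inhibitor), compound 1 gives 4520 nM, the lowest of the two numbers; compound 2 is the nearest and stands higher, beyond the scatter. Compound 3 `C#CCNC1CCc2c(SCCc3cccc(OC)c3)cccc21` is not yet measured. Its change from compound 1 is 3-methoxyphenyl in place of 4-methylphenyl on a saturated chain carbon, two bonds along the chain from a sulfur. Going by the values given here, no pair of measured compounds differs in one place, so the size of this kind of change is unknown here; no step beyond the scatter is expected in either direction. For compound 3 the expected value is 4500 nM, with a range from 1500 nM to 13000 nM. The expected step is a 1.0-fold lower number from compound 1 to compound 3 (0.00 log units; within the scatter).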

Compound 3, half-maximal inhibitory concentration: 3820 nM
Estimate against measurement, compound 3: 1.2-fold (0.07 log units) above; low and high end bracket the measured number.
By their numbers in this assay, from the lowest: compounds 3 and 1 (each within the scatter of the next); then compound 2.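

In this assay, going by these compounds alone, the step of a 1.2-fold lower number from compound 1 to compound 3 (0.07 log units; within the scatter) is the first readable change. On a saturated chain carbon, two bonds along the chain from a sulfur, 3-methoxyphenyl and 4-methylphenyl give values within the scatter of each other, even though the 3-methoxyphenyl group carries a hydrogen-bond acceptor. No available evidence bears on this result.

As far as these compounds go, whether an amine or a carboxylic acid in place of the substituted phenyl group keeps the value in this range remains open. From the compounds shown here alone, the effect of a longer chain between the sulfur and the phenyl group also remains open.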